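A few compounds are considered here, and "the series" means these few. Any claim that something is new, unique, unknown or untested is made for them only; others in the source may bear on it.

Among the compounds with values here, compound 2 `CC(=O)c1ccc(-c2cn3ccnc3c(-c3ccc4ncn(C5CCCCC5)c4c3)n2)cc1` is one of two compounds so far measured in a functional assay on NCI-H23 cells (Homo sapiens) for inhibition, read by sulforhodamine B assay, with a stated time of 48 h, tested at 10 uM; a lower number here means less inhibition, a higher number more inhibition at the concentration tested (going by the name of the read-out). In this assay compound 2 gives 8.6%, the lower of the two numbers, and compound 1 `Brc1cn2ccnc2c(-c2ccc3ncn(C4CCCCC4)c3c2)n1` gives 10.2%; the two values lie within the usual scatter of each other. Within the data shown here, the only measured step, a number 1.6 percentage points lower from compound 1 to compound 2 (within the scatter), brings 4-acetylphenyl in place of bromo on an aromatic carbon. Compound 3 `c1csc(-c2cn3ccnc3c(-c3ccc4ncn(C5CCCCC5)c4c3)n2)c1` has not yet been measured in this assay; it differs from compound 2 as follows: thiophen-2-yl in place of 4-acetylphenyl on an aromatic carbon. The step from compound 1 to compound 2 is the only one that bears on this change, and it stayed within the scatter, so no step beyond the scatter is expected in this assay for compound 3. Compound 3 is therefore estimated to give about 10%, with a range from 0% to 25%. The expected step is a number 1.4 percentage points higher from compound 2 to compound 3 (within the scatter).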

Compound 3, a percentage reported as inhibition, at one concentration (the size of the read-out at that concentration, not a potency): 5.95%
The estimate for compound 3 lay 4.1 percentage points above the measured number; measured number inside the range.
By their numbers in this assay, from the lowest: compounds 3, 2 and 1 (each within the scatter of the next).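

In this assay, thiophen-2-yl at this aromatic carbon next to the ring nitrogen gives a number 2.7 percentage points lower from compound 2 to compound 3 (within the scatter), and against bromo it gives a number 4.3 percentage points lower from compound 1 to compound 3 (within the scatter). The position has now taken a bromo, a six-membered aromatic ring of carbon only and a five-membered aromatic ring with a sulfur, and all three compounds lie within the scatter of one another, so the change of ring size and the loss of the acetyl group leave no readable mark on the number. Nothing on hand offers an explanation for this sameness. Going by these compounds, it remains open whether any group at this position can move the number beyond the scatter, for instance an amine, a carboxylic acid or a longer chain. On these data alone, it is also open whether a change elsewhere on the shared core would do so.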